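A ring swap on a compound at the assay limit

A few compounds are considered here, and "the series" means these few. Any claim that something is new, unique, unknown or untested is made for them only; others in the source may bear on it.

Measured in a functional assay on A549 cells (Homo sapiens), read by MTT assay, with a stated time of 72 h; on this read-out lower numbers stand for stronger inhibition and higher numbers for weaker inhibition:
- Compound 1 `CSc1ncnc2c1c(-c1cccs1)cn2[C@@H]1O[C@H](CO)[C@@H](O)[C@H]1O`: > 20000 nM, a limit of the assay
- Compound 2 `C#Cc1cn([C@@H]2O[C@H](CO)[C@@H](O)[C@H]2O)c2ncnc(SC)c12`: 140 nM
- Compound 3 `CNc1ncnc2c1c(-c1cccs1)cn2[C@@H]1O[C@H](CO)[C@@H](O)[C@H]1O`: > 20000 nM, a limit of the assay

Compound 3 stands at the limit of > 20000 nM in this assay, at which 2 of the 3 values shown sit. It therefore offers a limit and no number to start from.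

Compound 4 `CNc1ncnc2c1c(-c1cc3ccccc3o1)cn2[C@@H]1O[C@H](CO)[C@@H](O)[C@H]1O` keeps the methylamino group of compound 3 and differs in one place: 1-benzofuran-2-yl in place of thiophen-2-yl on an aromatic carbon. In short, 1-benzofuran-2-yl takes the place of thiophen-2-yl on an aromatic carbon.

Within the data shown here, two measured steps bear on this. The first changes the same carbon and is large: an at least 140-fold lower number from compound 1 to compound 2 (2.15 log units; beyond the scatter). However, it leads to ethynyl, which has no ring, so it says little about one ring group replacing another. The second changes a different place and cannot be sized: a step that the two limits leave unreadable from compound 1 to compound 3.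

Both compounds with thiophen-2-yl on that carbon sit at the limit, and compound 2, with ethynyl, goes against that. Compound 4 keeps an aromatic ring there, so no large gain in this assay is expected. The expected outcome is a number no higher from compound 3 to compound 4 (the limit leaves the size open). Compound 4 is estimated at 20000 nM. For compound 4 the expected range runs from 6000 nM to 40000 nM.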

Compound 4, half-maximal inhibitory concentration: > 20000 nM
Compound 4 gave a limit, no number; the forecaster's own chance of this, stated with the estimate: 70%; the middle value lies on the limit itself.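

In this assay compound 4 gives > 20000 nM, a limit of the assay and not a number. Compound 3 also stands at a limit, so no step can be read between compound 3 and compound 4. The values gather at one point: the limit of > 20000 nM in this assay, at which 3 of the 4 values shown sit.

The compounds shown leave open whether 1-benzofuran-2-yl and thiophen-2-yl differ at all on this carbon.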